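A few compounds are considered here, and "the series" means these few. Any claim that something is new, unique, unknown or untested is made for them only; others in the source may bear on it.

Compound 1 `O=C1C[C@H](O)C[C@@H](/C=C/c2c(Cl)cc(Cl)cc2-c2cc(Cl)cc(Cl)c2)O1` gives 37 nM in an assay for inhibition of 3-hydroxy-3-methylglutaryl-coenzyme A reductase (Rattus norvegicus) (on this read-out lower numbers stand for stronger inhibition and higher numbers for weaker inhibition), the highest number among the three measured compounds. Compound 3 `Cc1cc(C)c(CCC2C[C@@H](O)CC(=O)O2)c(-c2ccc(F)c(C)c2)c1` stands nearest to it with 22 nM, a gap that lies within the usual scatter, while compound 2 `Cc1cc(Cl)c(/C=C/[C@@H]2C[C@@H](O)CC(=O)O2)c(-c2ccc(F)c(C)c2)c1` stands furthest away with 13 nM, a gap beyond it. Compound 4 `CCc1cccc(-c2cc(Cl)cc(Cl)c2/C=C/[C@@H]2C[C@@H](O)CC(=O)O2)c1` has not yet been measured in this assay. It differs from compound 1 in a single place: 3-ethylphenyl in place of 3,5-dichlorophenyl on an aromatic carbon. Among the compounds with values here, no measured pair isolates this change, so any expectation rests only on the three values shown. Since compound 2 gives 13 nM and compound 3 gives 22 nM, both lower than compound 1, a small downward step is expected, a 1.7-fold lower number from compound 1 to compound 4 (0.23 log units; within the scatter), possibly still within the scatter. For compound 4 the expected value is 22 nM, with a range from 8 nM to 60 nM.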

Compound 4, half-maximal inhibitory concentration: 44 nM
Compound 4: middle estimate off by 2.0-fold (0.30 log units), on the low side; measured number inside the range.
By their numbers in this assay, from the lowest: compounds 2, 3, 1 and 4 (each within the scatter of the next, the first and the last beyond it).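

In this assay, within the data shown here, 3-ethylphenyl in place of 3,5-dichlorophenyl on this aromatic carbon gives a 1.2-fold higher number from compound 1 to compound 4 (0.08 log units; within the scatter), the first direct reading at this position. In this pair, the two chloro groups on the departing ring can be given up for a single ethyl group without a change beyond the scatter. Nothing measured here accounts for this result. On these data alone, the finding rests on one pair, so it remains open whether this position would also accept a smaller phenyl without substituents. As far as these compounds go, a ring bearing an amine or a carboxylic acid also remains untested here.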